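Notes on the 5-carboxythiophen-2-yl analogue

This account rests on a few compounds, and the source may have more. Where it says the series, first, only, none or still open, it means among the compounds named here.

In a physicochemical assay for solubility (on this read-out lower numbers stand for lower solubility and higher numbers for higher solubility), compound 1 (`CCOc1ccc(-c2nc(-c3ccc(C(=O)O)cc3)cs2)cc1OCC`) gives 23000 ug/mL, compound 2 (`CCOc1ccc(-c2nc(-c3ccccc3C(=O)O)cs2)cc1OCC`) gives 21000 ug/mL and compound 3 (`CCOc1ccc(-c2nc(-c3ccc(C(=O)O)o3)cs2)cc1OCC`) gives 23000 ug/mL. Compound 3 stands level with compound 1, and compound 2 lies within the scatter of both. Compound 4 (`CCOc1ccc(-c2nc(-c3ccc(C(=O)O)s3)cs2)cc1OCC`) carries 5-carboxythiophen-2-yl in place of 5-carboxyfuran-2-yl on an aromatic carbon. Among the compounds with values here, no pair of measured compounds differs in one place, so no direct step guides this change. The only anchor is the close agreement of the three values, with compound 3 at 23000 ug/mL. In this assay, the expected change, a 1.2-fold lower number from compound 3 to compound 4 (0.06 log units; within the scatter), stays within the scatter. For compound 4 the estimate is 20000 ug/mL, with an expected range of 10000 ug/mL to 35000 ug/mL.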

Compound 4, solubility: 23000 ug/mL
For compound 4 the middle estimate is 1.2-fold (0.06 log units) below the measured one, and the stated range covers the measured number.
By their numbers in this assay, from the lowest: compounds 2, 1, 3 and 4 (each within the scatter of the next).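

Within the data shown here, this is the first one-place step: in this assay, 5-carboxythiophen-2-yl in place of 5-carboxyfuran-2-yl on an aromatic carbon gives no change at the digits printed from compound 3 to compound 4 (within the scatter), so the read-out holds when the hetero atom of the five-membered aromatic ring goes from oxygen to sulfur. The two groups have the same counts of heavy atoms, hydrogen-bond donors and hydrogen-bond acceptors. No measurement bears on why the two compounds read alike.

Still open, going by these compounds, is how this assay responds when an amine or a primary amide replaces the carboxylic acid on the thiophene. On these data alone, a plain thiophen-2-yl at the same aromatic carbon is equally open.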